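Swapping isopropyl for cyclohexyloxy on a sugar-linked aryl ether

The compounds below may be only part of what the source reports. "The series", "measured", "known", "first", "only" and "open" are said of these compounds alone.

Compound 1 `CO[C@H]1O[C@H](COc2ccc(OC3CCCCC3)cc2)[C@@H](O)[C@H](O)[C@H]1Oc1ccc(OC2CCCCC2)cc1`: 14000 nM
Compound 2 `CO[C@@H]1O[C@H](COc2ccc(OC3CCCCC3)cc2)[C@@H](O)[C@H](O)[C@H]1Oc1ccc(C(C)C)cc1`: 26000 nM

Of the compounds shown here, two have been measured in a functional assay on HeLa cells (Homo sapiens) for cytotoxicity, read by MTT assay, with a stated time of 48 h; on this read-out lower numbers stand for an effect already at smaller amounts and higher numbers for an effect only at larger amounts of compound. Compound 1 gives 14000 nM in this assay. Compound 2 carries an isopropyl group in place of the second cyclohexyloxy group of compound 1; in this assay compound 2 gives 26000 nM. Compound 2 has the higher of the two numbers, but the gap to compound 1 lies within the scatter, so the two values cannot be told apart.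

The next compound, compound 3 `CO[C@@H]1O[C@H](COc2ccc(OC3CCCCC3)cc2)[C@@H](O)[C@H](O)[C@H]1Oc1ccc(OC2CCCCC2)cc1`, has not yet been measured. It differs from compound 2 in one place: cyclohexyloxy in place of isopropyl on an aromatic carbon. The group that enters is the same kind of group that compound 1 carries at that position.

Since compound 1 and compound 2 sit within the scatter of each other, the same change is expected to bring no step beyond the scatter, with a 1.6-fold lower number from compound 2 to compound 3 (0.21 log units; within the scatter) estimated as small, if anything toward a slightly lower number. Compound 3 is therefore expected to give about 16000 nM in this assay, within a range from 7000 nM to 35000 nM.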

Compound 3, half-maximal effective concentration: 14000 nM
Compound 3: the middle estimate sits 1.1-fold (0.06 log units) above what was measured; low and high end bracket the measured number.
By their numbers in this assay, from the lowest: compounds 1, 3 and 2 (each within the scatter of the next).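

In this assay, cyclohexyloxy in place of isopropyl on an aromatic carbon gives a 1.9-fold lower number from compound 2 to compound 3 (0.27 log units; within the scatter), so this position accepts either group without a readable difference, even though only cyclohexyloxy brings a ring and a hydrogen-bond acceptor. This is a cleaner reading than the earlier comparison of compound 1 with compound 2, which mixed the change of group with a change in configuration. Compound 3 also separates out the configuration at one saturated ring carbon, with no change at the digits printed from compound 1 to compound 3 (within the scatter), and this step can be read as a pure test of configuration for one reason: the fact that compounds 1 and 3 differ only in the configuration as drawn

The compounds shown leave open whether a group of another kind on this aromatic carbon, such as an amine, a carboxylic acid or a longer chain, would move the number beyond the scatter. They also leave open whether the configuration at that ring carbon would still make no readable difference with isopropyl in place of cyclohexyloxy, and whether changing the other cyclohexyloxy group would matter.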